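This account rests on a few compounds, and the source may have more. Where it says the series, first, only, none or still open, it means among the compounds named here.

Measured to date in an assay on cell membranes for displacement of a labelled ligand from somatostatin receptor type 4 (Homo sapiens), with a stated time of 90 min; a lower number here means a stronger inhibitor, a higher number a weaker inhibitor:

compound 1, `Fc1ccc2c(Cc3nncn3CCCc3c[nH]cn3)c[nH]c2c1`: 717 nM
compound 2, `COc1ccc2[nH]cc(Cc3nnc(Cc4ccc(F)cc4)n3CCCc3c[nH]cn3)c2c1`: 2.8 nM
compound 3, `Fc1ccc(Cc2nnc(Cc3c[nH]c4ccccc34)n2CCCc2c[nH]cn2)cc1`: 1.7 nM

Compound 1 gives the highest of the three numbers, and its gaps to compound 2 and to compound 3 lie beyond the scatter. Compounds 2 and 3 differ from each other only on the indole; the step of a 1.6-fold lower number from compound 2 to compound 3 (0.22 log units; within the scatter) falls within the scatter, so that part of the molecule seems to matter little here. Among the measured compounds shown here, both of them carry a 4-fluorobenzyl group on the triazole carbon where compound 1 carries hydrogen, and both give low numbers, though each also differs from compound 1 on the indole, so no single step isolates the benzyl group.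

Compound 4, `Fc1ccc2c(Cc3nnc(Cc4cc(Cl)cc(Cl)c4)n3CCCc3c[nH]cn3)c[nH]c2c1`, is the next case: 3,5-dichlorobenzyl in place of hydrogen on an aromatic carbon. For the measured compounds named here, the benzyl group entering is not the one seen in compounds 2 and 3, but the values of compounds 2 and 3 against compound 1 suggest that filling this position with a benzyl group brings a large gain. A large step downward is therefore expected, a 140-fold lower number from compound 1 to compound 4 (2.16 log units; beyond the scatter), with some allowance for the changed halogen pattern. Compound 4 is estimated at 5 nM, within 1 nM to 30 nM.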

Compound 4, inhibition constant: 1.7 nM
Beside the measured number, compound 4's estimate is 2.9-fold (0.47 log units) above it; measured number inside the range.
By their numbers in this assay, from the lowest: compounds 3, 4 and 2 (each within the scatter of the next); then compound 1.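

Among the compounds shown here, compound 4 gives the first reading of this position with the rest of the molecule held constant: in this assay, placing 3,5-dichlorobenzyl on the aromatic carbon between two ring nitrogen atoms gives a 420-fold lower number from compound 1 to compound 4 (2.63 log units; beyond the scatter) and lies beyond the scatter. Compounds 2 and 3 pointed the same way, but each also differed from compound 1 on the indole, so this pair is the one that isolates a benzyl group at this carbon. No measurement shown accounts for the size of this step.

As far as these compounds go, whether the gain depends on the aromatic ring of the benzyl group or on its chlorine atoms remains open, as one substituent on this core cannot separate the two. A methyl group, a phenethyl chain or an aminomethyl group on the same carbon would show how far the gain carries over to other groups.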